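A few compounds are considered here, and "the series" means these few. Any claim that something is new, unique, unknown or untested is made for them only; others in the source may bear on it.

Among the compounds with values here, compound 2 `CNc1nc(Cl)nc(NC2(C#N)CCCCC2)n1` gives 1070 nM in an in vitro assay on Sf21 cells for inhibition of high affinity 3',5'-cyclic-AMP phosphodiesterase 7A (Homo sapiens) (a higher number here means a weaker inhibitor, a lower number a stronger inhibitor), the only number so far. Compound 1 `CNc1nc(NC2(C#N)CCCCC2)nc(-n2cccn2)n1` returns a limit there, > 5000 nM. Compound 3 `CNc1nc(NC2(C#N)CCCCC2)nc(-n2cnc(C#N)n2)n1` carries 3-cyano-1H-1,2,4-triazol-1-yl in place of chloro on an aromatic carbon. Within the data shown here, the one measured step, an at least 4.6-fold lower number from compound 1 to compound 2 (0.66 log units; beyond the scatter), exchanged a five-membered azole for chloro; the change to compound 3 puts a five-membered azole back in place of chloro, so the limit of > 5000 nM in this assay, at which 1 of the 2 values shown sits, indicates that the number may well climb back toward the limit, with a fair chance that only a limit is reported. The expected step is a 3.7-fold higher number from compound 2 to compound 3 (0.57 log units; beyond the scatter). Compound 3 is estimated at 4000 nM, with a range from 1200 nM to 15000 nM.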

Compound 3, half-maximal inhibitory concentration: > 5000 nM
Compound 3 ended at the assay's limit (the forecaster's own chance of this, stated with the estimate: 45%); at least 1.2-fold (0.09 log units) between middle value and limit.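

Exchanging chloro for 3-cyano-1H-1,2,4-triazol-1-yl gives an at least 4.6-fold higher number from compound 2 to compound 3 (0.66 log units; beyond the scatter) in this assay, so at this position on the shared core chloro now outperforms two different five-membered aromatic rings, 1H-pyrazol-1-yl and this triazole. The step from compound 1 to compound 3 cannot be read, as both values are limits, and the two azoles cannot be ranked. Only compound 2 gives a number in this small set: the limit of > 5000 nM in this assay, at which 2 of the 3 values shown sit.

As far as these compounds go, whether a methoxy group, a bromine or a primary amine at this position would match compound 2 remains open. From the compounds shown here alone, how weak compound 1 and compound 3 actually are also remains open.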